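Cytotoxicity on MT4 cells: from compound 2 to compound 3

The compounds below may be only part of what the source reports. "The series", "measured", "known", "first", "only" and "open" are said of these compounds alone.

Compound 1: `Cc1cn([C@@H]2O[C@H](CO[Si](C)(C)C(C)(C)C)[C@@]3(OS(=O)(=O)C=C3NCC(=O)C(=O)N3CCC3)[C@H]2O[Si](C)(C)C(C)(C)C)c(=O)n(C)c1=O`, 17400 nM
Compound 2: `CCOC(=O)CNC(=O)NC1=CS(=O)(=O)O[C@@]12[C@@H](CO[Si](C)(C)C(C)(C)C)O[C@@H](n1cc(C)c(=O)n(C)c1=O)[C@@H]2O[Si](C)(C)C(C)(C)C`, 3780 nM

In a functional assay on MT4 cells (Homo sapiens) (a lower number here means that less compound is tolerated, a higher number that more compound is tolerated), compound 2 gives the lowest of the two numbers; compound 1 sits a 4.6-fold lower number from compound 1 to compound 2 (0.66 log units; beyond the scatter) away. Compound 3 is `Cc1cn([C@@H]2O[C@H](CO[Si](C)(C)C(C)(C)C)[C@@]3(OS(=O)(=O)C=C3NCCC(=O)O)[C@H]2O[Si](C)(C)C(C)(C)C)c(=O)n(C)c1=O`; it differs from compound 2 by 2-carboxyethyl in place of ((ethoxycarbonyl)methyl)carbamoyl on an amine nitrogen. Within the data shown here, no measured step covers this exact exchange; only the step between compound 1 and compound 2, at the same amine nitrogen, is known, and it was modest. Compound 3 is therefore expected to move modestly upward, a 2.0-fold higher number from compound 2 to compound 3 (0.30 log units; within the scatter), with wide uncertainty. The estimate for compound 3 is 7500 nM, between 2500 nM and 22000 nM.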

Compound 3, half-maximal cytotoxic concentration: 11500 nM
The estimate for compound 3 lay 1.5-fold (0.19 log units) below the measured number; low and high end bracket the measured number.
By their numbers in this assay, from the lowest: compound 2; then compounds 3 and 1 (each within the scatter of the next).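

In this assay, 2-carboxyethyl in place of ((ethoxycarbonyl)methyl)carbamoyl on the amine nitrogen gives a 3.0-fold higher number from compound 2 to compound 3 (0.48 log units; beyond the scatter) and so reverses most of the earlier step. Carboxymethyl in place of ((azetidin-1-yl)carbonyl)carbonyl on the saturated chain carbon gives a 1.5-fold lower number from compound 1 to compound 3 (0.18 log units; within the scatter) and thus no change that can be read, so among these three compounds only compound 2 stands apart. The compounds shown leave open whether the carboxylic acid of compound 3 matters here, or whether an ethyl ester or an amine at the end of that chain would read the same. No supporting data bear on these differences.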